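The compounds below may be only part of what the source reports. "The series", "measured", "known", "first", "only" and "open" are said of these compounds alone.

Working notes on the series. The shared core carries a 2,6-difluorobenzyl group and a 3-methoxyphenyl group; the variation sits on the aromatic nitrogen two atoms from the ring nitrogen. Compound 1 `COc1cccc(-c2c(C)n(Cc3c(F)cccc3F)c(=O)n([C@H](C)CNCC(C)C)c2=O)c1` gives 190 nM in an assay on HEK293 cells for binding affinity to Gonadotropin-releasing hormone receptor (Homo sapiens); a lower number here means a stronger inhibitor, a higher number a weaker inhibitor. Compound 2 `COc1cccc(-c2c(C)n(Cc3c(F)cccc3F)c(=O)n([C@H](C)CNCc3cccc(F)c3)c2=O)c1` gives 85 nM in this assay. The one measured step, a 2.2-fold lower number from compound 1 to compound 2 (0.35 log units; beyond the scatter), comes from 3-fluorophenyl in place of isopropyl on a saturated chain carbon bound to an amine nitrogen is not a listed difference, so it is described here only as the change from isopropyl to 3-fluorophenyl on the chain carbon bound to the amine nitrogen. Compound 2 therefore stands at the lower of the two numbers, separated from compound 1 by a step beyond the scatter.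

Compound 3 `COc1cccc(-c2c(C)n(Cc3c(F)cccc3F)c(=O)n(C3CCN(Cc4ccccc4)C3)c2=O)c1` is not yet measured. It differs from compound 2 by 1-benzylpyrrolidin-3-yl in place of 1-(((3-fluorobenzyl)amino)methyl)ethyl on an aromatic nitrogen. Among the compounds with values here, no measured step bears directly on closing the chain into a ring and removing the hydrogen-bond donor; the step of a 2.2-fold lower number from compound 1 to compound 2 (0.35 log units; beyond the scatter) speaks only for keeping an aromatic ring on the amine side, which compound 3 retains as a benzyl group. With that single indirect precedent, the step of a 1.3-fold higher number from compound 2 to compound 3 (0.11 log units; within the scatter) is expected to stay within or near the scatter, with no direction called. Compound 3 is accordingly estimated at 110 nM in this assay, with a range from 30 nM to 400 nM.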

Compound 3, inhibition constant: 280 nM
Compound 3: middle estimate off by 2.5-fold (0.41 log units), on the low side; the range from low to high includes it.
By their numbers in this assay, from the lowest: compound 2; then compounds 1 and 3 (each within the scatter of the next).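

In this assay, 1-benzylpyrrolidin-3-yl on the aromatic nitrogen in place of 1-(((3-fluorobenzyl)amino)methyl)ethyl gives a 3.3-fold higher number from compound 2 to compound 3 (0.52 log units; beyond the scatter), so the advantage of compound 2 is not kept by a group that retains a six-membered aromatic ring of carbon only but has a five-membered non-aromatic ring, no fluorine and no hydrogen-bond donor. Against 1-((isobutylamino)methyl)ethyl, the same group gives a 1.5-fold higher number from compound 1 to compound 3 (0.17 log units; within the scatter), so at this position an aromatic ring in the side group does not by itself separate compound 3 from compound 1, whose group has none. No supporting data are available to explain either step.

From the compounds shown here alone, the step from compound 2 changes the ring, the fluorine, the hydrogen-bond donor and the defined stereocentre together, so the share of each remains open. A 1-(3-fluorobenzyl)pyrrolidin-3-yl group would test the fluorine within the closed ring, and an open chain with a methyl group on the amine nitrogen would test the loss of the amine hydrogen without ring closure.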